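The source may report more compounds than this note shows. Statements on the series, on what has been measured and on what is new or still open speak of the compounds shown alone.

Measured so far:
compound 1, `COc1ccc(C(=O)Nc2sc3c(c2C#N)CCN(C(=O)c2cc(C(C)C)n[nH]2)C3)cc1`, "not determined" (no result reported) in a functional assay on Chem-3 cells for antagonist activity at metabotropic glutamate receptor 1 (Homo sapiens), read by fluorescence and calcium flux; on this read-out higher numbers stand for weaker inhibition and lower numbers for stronger inhibition;
compound 2, `CC(C)c1cc(C(=O)N2CCc3c(sc(NCc4ccccc4)c3C#N)C2)[nH]n1`, 43200 nM in this assay.

Among the compounds with values here, compound 2 gives the only number in this assay, and it stands at weak inhibition; compound 1 gives none. Compound 3, `N#Cc1c(NCc2ccccc2)sc2c1CCN(C(=O)c1ccccc1)C2`, has not yet been measured. It differs from compound 2 in one place: phenyl in place of 3-isopropyl-1H-pyrazol-5-yl on a carbonyl carbon. Within the data shown here, no step between measured compounds is available, so nothing measured here shows what this change does. The step of a 1.2-fold lower number from compound 2 to compound 3 (0.09 log units; within the scatter) is expected to stay within the usual scatter, in no clear direction. Compound 3 is therefore estimated at 35000 nM, with a range from 8000 nM to 100000 nM.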

Compound 3, half-maximal inhibitory concentration: 2820 nM
Estimate against measurement, compound 3: 12-fold (1.09 log units) above; measured number below the stated range.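

In this assay, phenyl in place of 3-isopropyl-1H-pyrazol-5-yl on the carbonyl carbon gives a 15-fold lower number from compound 2 to compound 3 (1.19 log units; beyond the scatter) and so stronger inhibition. Within the data shown here, the group at this position therefore matters for inhibition on the shared core, a point the single earlier number could not show. Nothing available explains the shift.

As far as these compounds go, it remains open whether a pyridyl or cyclohexyl group on the same carbonyl carbon would behave like phenyl. From the compounds shown here alone, it is also open whether an unsubstituted pyrazolyl group would give a number nearer that of compound 2 or that of compound 3.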